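Replacing hydroxy with fluoro on compound 3

The source may report more compounds than this note shows. Statements on the series, on what has been measured and on what is new or still open speak of the compounds shown alone.

In a functional assay on HeLa cells (Homo sapiens) for antiproliferative activity, read by sulforhodamine B assay, with a stated time of 48 h (on this read-out higher numbers stand for weaker inhibition and lower numbers for stronger inhibition), compound 1 (`COc1ccc(C(=O)/C=C\Nc2ccc(-c3nc4cc(OC)c(OC)c(OC)c4s3)cc2C)cc1O`) gives 11400 nM, compound 2 (`COc1cc(OC)c2sc(-c3ccc(N/C=C\C(=O)c4ccc(OC)c(O)c4)cc3)nc2c1`) gives 12100 nM and compound 3 (`COc1ccc(C(=O)/C=C\Nc2ccc(-c3nc4cc(OC)c(OC)c(OC)c4s3)cc2)cc1O`) gives 14100 nM. These three numbers lie within the usual scatter of one another, so compound 3 stands level with the other two.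

The next compound to be measured is compound 4 (`COc1ccc(C(=O)/C=C\Nc2ccc(-c3nc4cc(OC)c(OC)c(OC)c4s3)cc2)cc1F`), which differs from compound 3 in one place: fluoro in place of hydroxy on an aromatic carbon. This puts fluoro in place of hydroxy on an aromatic carbon, turning 3-hydroxy-4-methoxyphenyl into 3-fluoro-4-methoxyphenyl.

Two measured steps offer indirect guidance. Hydrogen in place of methyl on an aromatic carbon gives a 1.2-fold higher number from compound 1 to compound 3 (0.09 log units; within the scatter). Methoxy in place of hydrogen on an aromatic carbon gives a 1.2-fold higher number from compound 2 to compound 3 (0.07 log units; within the scatter). Going by the values given here, both changes lie away from the hydroxy, which all three measured compounds carry, so this swap has no direct precedent here. They show only that these two edits stayed within the scatter, so no clear direction can be predicted and the range must stay wide.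

The expected change is small, an estimated 1.1-fold higher number from compound 3 to compound 4 (0.03 log units; within the scatter), which would not stand beyond the scatter. For compound 4 the estimated value is 15000 nM, with an expected range of 6000 nM to 38000 nM.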

Compound 4, half-maximal inhibitory concentration: 7300 nM
Estimate against measurement, compound 4: 2.1-fold (0.31 log units) above; the measured number falls inside the stated range.
By their numbers in this assay, from the lowest: compounds 4, 1, 2 and 3 (each within the scatter of the next).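

In this assay, going by these compounds alone, the swap gives a 1.9-fold lower number from compound 3 to compound 4 (0.29 log units; within the scatter), the first direct test of the group on the aryl ketone ring that all the earlier compounds shared, at the ring position ortho to a methoxy group. Because that step stays within the scatter, compound 4 stands level with compound 3, even though the hydroxy, counted as one hydrogen-bond donor and one acceptor, gives way to a fluoro counted as neither, so at this read-out the activity does not depend on keeping the hydroxy at this position. Nothing available explains why the two compounds stand level, and one swap at this position cannot show how the group acts in the cells.

The compounds shown leave open whether other groups at this position, such as an amine, a chloro or a longer alkoxy chain, would also stay level or would move the number beyond the scatter. They also leave open whether the same swap would hold up on compound 1 or compound 2, where the rest of the molecule differs in one place from compound 3.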